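Compound 4 against compound 2: a methyl for a methoxy

The compounds below may be only part of what the source reports. "The series", "measured", "known", "first", "only" and "open" are said of these compounds alone.

Compound 1 `O=C(Nc1nc2ccc(F)cc2s1)N1CCN(c2ccc(Cl)nn2)CC1` — in an assay on HEK293 cells for inhibition of transient receptor potential cation channel subfamily V member 1 (Homo sapiens), read by FLIPR (on this read-out higher numbers stand for weaker inhibition and lower numbers for stronger inhibition), compound 1 gives > 10000 nM, a limit of the assay.
Compound 2 `COc1ccc(N2CCN(C(=O)Nc3nc4ccc(F)cc4s3)CC2)nn1` — in this assay compound 2 gives > 10000 nM, also a limit.
Compound 3 `O=C(Nc1ccc(OC(F)(F)F)cc1)N1CCN(c2ccc(-c3ccccc3)nn2)CC1` — in this assay compound 3 gives > 10000 nM, again a limit.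

Compound 2 therefore stands at the limit, the level at which every measured value sits (the limit of > 10000 nM in this assay, at which 3 of the 3 values shown sit). Compound 4 `Cc1ccnnc1N1CCN(C(=O)Nc2nc3ccc(F)cc3s2)CC1` differs from compound 2 by 4-methylpyridazin-3-yl in place of 6-methoxypyridazin-3-yl on an amine nitrogen in a ring. Among the measured compounds shown here, the only measured step at this part of the molecule, a step that the two limits leave unreadable from compound 1 to compound 2, runs between two limits, so neither its size nor its direction can be read, and it gives no guide for the new change. The estimated step is a step that the limit leaves unreadable from compound 2 to compound 4, in other words no readable change. Compound 4 is thus expected at 15000 nM, within 5000 nM to 50000 nM, and most likely to be reported once more as a limit.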

Compound 4, half-maximal inhibitory concentration: 6170 nM
Compound 4: the middle estimate sits 2.4-fold (0.39 log units) above what was measured; low and high end bracket the measured number.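

In this assay, compound 4 is the one compound shown that gives a number rather than a limit: the limit of > 10000 nM in this assay, at which 3 of the 4 values shown sit. Placing 4-methylpyridazin-3-yl on the amine nitrogen in the ring gives an at least 1.6-fold lower number from compound 2 to compound 4 (0.20 log units; that floor lies within the scatter), and the same group gives an at least 1.6-fold lower number from compound 1 to compound 4 (0.20 log units; that floor lies within the scatter). Both are floors only, so the change may be larger but is not shown to exceed the scatter, and the step between the two limits cannot be read.

Going by these compounds, it remains open how far the true values of compound 1 and compound 2 lie from compound 4. On these data alone, it is also open whether an ethyl group or an amine in place of the methyl would give a readable value.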